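Removing One Methoxy Group and Cytotoxicity on Vero Cells

The compounds below may be only part of what the source reports. "The series", "measured", "known", "first", "only" and "open" are said of these compounds alone.

Four compounds share one core and differ only in the methoxy groups on the outer six-membered ring. Compound 1 `COc1ccc(-c2nc3cc(C(F)(F)F)ccc3[nH]2)c(OC)c1` carries two methoxy groups, as does compound 3 `COc1cc(OC)cc(-c2nc3cc(C(F)(F)F)ccc3[nH]2)c1`, while compound 2 `COc1ccc(-c2nc3cc(C(F)(F)F)ccc3[nH]2)cc1` and the not yet measured compound 4 `COc1cccc(-c2nc3cc(C(F)(F)F)ccc3[nH]2)c1` carry one each. The difference between the core of compound 1 and the core of compound 3 is not broken down here.

In an ADME assay on Vero cells (Chlorocebus sabaeus) for cytotoxicity (on this read-out lower numbers stand for higher toxicity in this test and higher numbers for lower toxicity in this test), compound 1 gives only a limit of the assay, > 100000 nM. In this assay compound 2 gives 15000 nM. Compound 3 likewise gives only a limit, > 100000 nM. The change from compound 1 to compound 2 is hydrogen in place of methoxy on an aromatic carbon, and it produces an at least 6.6-fold lower number from compound 1 to compound 2 (0.82 log units; beyond the scatter). Its size is known only as a bound because the value of compound 1 sits at the limit of > 100000 nM in this assay, at which 2 of the 3 values shown sit.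

The change from compound 3 to compound 4 is hydrogen in place of methoxy on an aromatic carbon. It is the same kind of change, but not the same: in compound 1 the leaving methoxy is ortho to a large group, whereas in compound 3 it is meta to a large group; in both it is meta to a methoxy group.

For compound 4 the expected step is an at least 4.0-fold lower number from compound 3 to compound 4 (0.60 log units; beyond the scatter). This expectation rests on an at least 6.6-fold lower number from compound 1 to compound 2 (0.82 log units; beyond the scatter) and on the number given by compound 2, 15000 nM. Compound 4 is therefore estimated at 25000 nM, within a range from 8000 nM to 100000 nM.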

Compound 4, half-maximal cytotoxic concentration: > 100000 nM
Compound 4: a limit, no number (the forecaster's own chance of this, stated with the estimate: 30%); at least 4.0-fold (0.60 log units) between middle value and limit.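

In this assay compound 4 gives only a limit, > 100000 nM. Among the compounds shown here, compound 3 sits at the same kind of limit, so no step from compound 3 to compound 4 can be read: (the limit of > 100000 nM in this assay, at which 3 of the 4 values shown sit). The compounds shown leave open how far beyond this limit compound 3 and compound 4 lie, and so whether hydrogen in place of methoxy changes the number here at all.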